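The compounds below may be only part of what the source reports. "The series", "measured", "known", "first", "only" and "open" are said of these compounds alone.

In an assay on cells for antagonist activity at transient receptor potential cation channel subfamily V member 1 (Homo sapiens), read by FLIPR and calcium flux, with a stated time of 6 min (on this read-out lower numbers stand for stronger inhibition and higher numbers for weaker inhibition), three compounds have been measured so far:
compound 3 `CC1CCN(c2cc(C(C)(C)C)ccc2CNC(=O)C(C)c2ccc(NS(C)(=O)=O)c(F)c2)CC1` gives 0.7 nM;
compound 1 `CC(C)Oc1nc(C(C)(C)C)ccc1CNC(=O)C(C)c1ccc(NS(C)(=O)=O)c(F)c1` gives 2.3 nM;
compound 2 `CCOCCOc1nc(C(C)(C)C)ccc1CNC(=O)C(C)c1ccc(NS(C)(=O)=O)c(F)c1` gives 23.9 nM.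

Compound 3 stands lowest of the three numbers; compound 1 is nearest to it and compound 2 furthest. Compound 4 `CCCCSc1cc(C(C)(C)C)ccc1CNC(=O)C(C)c1ccc(NS(C)(=O)=O)c(F)c1` differs from compound 3 in one place: butylsulfanyl in place of 4-methylpiperidin-1-yl on an aromatic carbon. Among the measured compounds shown here, the only measured step, a 10-fold higher number from compound 1 to compound 2 (1.02 log units; beyond the scatter), exchanged one chain for another on an oxygen and was large, but it involves no ring leaving and no sulfur entering, so it bears on this change only loosely. For the measured compounds named here, no measured pair shows a swap of this kind, so a modest weakening in this assay is expected rather than a large one. Compound 4 is therefore estimated at 3 nM, within 0.8 nM to 12 nM. The expected step is a 4.3-fold higher number from compound 3 to compound 4 (0.63 log units; beyond the scatter).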

Compound 4, inhibition constant: 6.7 nM
Estimate against measurement, compound 4: 2.2-fold (0.35 log units) below; low and high end bracket the measured number.
By their numbers in this assay, from the lowest: compound 3; then compound 1; then compound 4; then compound 2.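

In this assay, butylsulfanyl in place of 4-methylpiperidin-1-yl gives a 9.6-fold higher number from compound 3 to compound 4 (0.98 log units; beyond the scatter) at this aromatic carbon, ortho to a large group. What sits on this carbon therefore matters, although an open chain joined through sulfur still leaves compound 4 at 6.7 nM in this assay. No measurement shown explains the step.

As far as these compounds go, it remains open whether the step comes from losing the ring or from gaining the sulfur. A butoxy or butylamino chain on this same carbon would help separate those two changes.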